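Propargyl to 4-chlorobenzyl: does compound 4 stay inactive?

The compounds below may be only part of what the source reports. "The series", "measured", "known", "first", "only" and "open" are said of these compounds alone.

In a functional assay on HCT-116 cells (Homo sapiens) for inhibition, read by WST assay, with stated times of 72 h and 2 h (a higher number here means a weaker inhibitor, a lower number a stronger inhibitor), compound 1 (`C#CCOC(c1cccs1)c1cc2ccccc2nc1Cl`) gives > 100000 nM as a limit of the assay and not as a number. So compound 1 has no exact position on the scale, and there is no measured potency from which to start.

Compound 4 (`Clc1ccc(COC(c2cccs2)c2cc3ccccc3nc2Cl)cc1`) differs from compound 1 by a single change (4-chlorophenyl in place of ethynyl on a saturated chain carbon bound to an oxygen on a saturated carbon) in which propargyl gives way to 4-chlorobenzyl. Among the compounds with values here, no pair of measured compounds shows the size of a comparable change on its own, so the expectation has to rest on close relatives. Compound 2 (`Oc1ccc(-c2cc(COC(c3cccs3)c3cc4ccccc4nc3Cl)on2)cc1`) also has a larger group in this place and is reported as "not active" (no number reported) in this test. Compound 3 (`FC(F)(F)c1cccc(COC(c2cccs2)c2cc3ccccc3nc2Cl)c1`) likewise has a larger group there and is reported as "not active" (no number reported) in the same test.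

The expected step of a number no higher from compound 1 to compound 4 (the limit leaves the size open) is therefore none beyond the usual scatter. For compound 4 the estimated value is 100000 nM with an expected range from 30000 nM to 200000 nM in this assay once it is measured.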

Compound 4, half-maximal inhibitory concentration: "not active" (no number reported)
Nothing numeric was reported for compound 4, so the estimate cannot be set against anything.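

Compound 4 is reported as "not active" with no number, and compound 1 has only a limit, not a measured value, so no step can be read from compound 1 to compound 4. The compounds shown leave open whether any group in this place gives a measurable potency in this assay, and the only figure available is a limit: the limit of > 100000 nM in this assay, at which 1 of the 4 values shown sits.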